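The source may hold more compounds than are shown below. What is called first, only, known or untested is meant among the compounds shown, and "the series" means these compounds.

Among the compounds with values here, in a functional assay on HepG2 cells (Homo sapiens) for inhibition, read by MTT assay (on this read-out higher numbers stand for weaker inhibition of growth and lower numbers for stronger inhibition of growth), compound 1 `COc1cc2oc(-c3cccc(NC(=O)c4ccc(Br)cc4)c3)cc(=O)c2c(OC)c1OC` gives 8850 nM, the lowest of the three numbers measured so far. Compound 2 `COc1cc2oc(-c3cccc(NC(=O)c4cccc(Br)c4)c3)cc(=O)c2c(OC)c1OC` gives 10900 nM, and a 1.2-fold higher number from compound 1 to compound 2 (0.09 log units; within the scatter), so the two are not separated. Compound 3 `COc1cc2oc(-c3cccc(NC(=O)c4ccc(F)cc4)c3)cc(=O)c2c(OC)c1OC` gives 47200 nM; a 5.3-fold higher number from compound 1 to compound 3 (0.73 log units; beyond the scatter), and a 4.3-fold higher number from compound 2 to compound 3 (0.64 log units; beyond the scatter). Compound 4 `COc1cc2oc(-c3cccc(NC(=O)c4ccc([N+](=O)[O-])cc4)c3)cc(=O)c2c(OC)c1OC` is not yet measured; relative to compound 1 it carries nitro in place of bromo on an aromatic carbon. Within the data shown here, the only measured exchange of the bromo group itself is that to fluoro, where a 5.3-fold higher number from compound 1 to compound 3 (0.73 log units; beyond the scatter) was a modest weakening of growth inhibition; no measured pair covers nitro. For compound 4 a step in this assay toward weaker growth inhibition of roughly that size, or none beyond the scatter, is expected, giving a 1.8-fold higher number from compound 1 to compound 4 (0.26 log units; within the scatter). The estimate for compound 4 is 16000 nM, within 5000 nM to 50000 nM.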

Compound 4, concentration for 50% growth inhibition: 18800 nM
Compound 4: the middle estimate sits 1.2-fold (0.07 log units) below what was measured; the measured number falls inside the stated range.
By their numbers in this assay, from the lowest: compounds 1, 2 and 4 (each within the scatter of the next, the first and the last beyond it); then compound 3.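

In this assay, nitro on this aromatic carbon separates from both halogens already tried: a 2.1-fold higher number from compound 1 to compound 4 (0.33 log units; beyond the scatter), while a 2.5-fold lower number from compound 3 to compound 4 (0.40 log units; beyond the scatter), so the outcome of replacing bromo here depends on the incoming group and the change is not uniformly one of a fixed size. Against the other bromo isomer there is no such separation: a 1.7-fold higher number from compound 2 to compound 4 (0.24 log units; within the scatter). Nothing available bears on what lies behind these differences. Open, going by these compounds, is where an amine or a carboxylic acid at this place would fall relative to the 4-bromophenyl and 4-fluorophenyl amides.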